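The source may report more compounds than this note shows. Statements on the series, on what has been measured and on what is new or still open speak of the compounds shown alone.

Compound 1 `C=C(C(=O)c1ccc(OC)cc1)C(OC(C)=O)c1ccc([N+](=O)[O-])cc1` was tested in a functional assay on MCF7 cells (Homo sapiens) for inhibition, read by XTT assay, with a stated time of 48 h (a lower number here means a stronger inhibitor, a higher number a weaker inhibitor), where compound 1 gives 6100 nM. For the measured compounds named here, its only measured neighbour is compound 2 `C=C(C(=O)c1ccc(OC)cc1OC)C(OC(C)=O)c1ccc([N+](=O)[O-])cc1`, which in this assay gives 10400 nM; the step of a 1.7-fold higher number from compound 1 to compound 2 (0.23 log units; within the scatter), methoxy in place of hydrogen on an aromatic carbon, leaves the two within scatter of each other. Compound 3 `C=C(C(=O)c1ccc(OC)cc1)C(OC(=O)c1ccccc1)c1ccc([N+](=O)[O-])cc1` differs from compound 1 by phenyl in place of methyl on a carbonyl carbon, acetoxy to benzoyloxy. Going by the values given here, no measured step touches this position, so the only guide is that the one change tried elsewhere on the shared core moved nothing beyond the scatter. Compound 3 is therefore expected to move only a little, an estimated step of a 1.2-fold lower number from compound 1 to compound 3 (0.09 log units; within the scatter). The estimate for compound 3 in this assay is 5000 nM, ranging from 1500 nM to 16000 nM.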

Compound 3, half-maximal inhibitory concentration: 56100 nM
Compound 3: the middle estimate sits 11-fold (1.05 log units) below what was measured, outside the stated range (above it).
By their numbers in this assay, from the lowest: compounds 1 and 2 (each within the scatter of the next); then compound 3.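

In this assay, for the compounds shown here, the acyl group on the oxygen is the first place on the shared core where a change moves the number beyond the scatter: acetoxy to benzoyloxy gives a 9.2-fold higher number from compound 1 to compound 3 (0.96 log units; beyond the scatter) and so a weaker inhibitor. This position therefore does not accept every replacement of methyl on the carbonyl carbon, whereas the methoxy step on the aromatic carbon stayed within the scatter. No available evidence accounts for this shift. The compounds shown leave open whether the phenyl ring itself matters or a longer chain such as propionyloxy would shift the number too, and how a free hydroxyl or an amide would fare here.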